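A Fluorine Added Next Door to Chlorine on a Shared Core

A few compounds are considered here, and "the series" means these few. Any claim that something is new, unique, unknown or untested is made for them only; others in the source may bear on it.

Of the compounds shown here, two built on the same core have so far been tested in a functional assay on PC-3 cells (Homo sapiens) for inhibition, read by MTT assay, with a stated time of 72 h; a lower number here means a stronger inhibitor, a higher number a weaker inhibitor. Compound 1, `O=C(CSc1nc(Nc2ccccc2)c2ccccc2n1)Nc1ccccc1F`, gives 12400 nM. Compound 2, `C=CC(=O)Nc1cccc(NC(=O)CSc2nc(Nc3cccc(Cl)c3)c3ccccc3n2)c1`, gives 12300 nM. Compound 2 has the lower of the two numbers, but the gap to compound 1 falls inside the usual scatter of repeated measurements, so the two results are best read as alike, and neither can be called the stronger inhibitor on this evidence.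

The next compound, compound 3, is `C=CC(=O)Nc1cccc(NC(=O)CSc2nc(Nc3ccc(F)c(Cl)c3)c3ccccc3n2)c1`. It is compound 2 with one small change: fluoro in place of hydrogen on an aromatic carbon. The fluoro group sits on the six-membered aromatic ring of carbon only, on the carbon ortho to a chloro group, and para to a large group, so the 3-chlorophenyl becomes a 3-chloro-4-fluorophenyl.

Among the compounds with values here, no step between measured compounds exists to guide this change. With only a single fluorine entering, and with the two measured compounds so close to each other, the step expected from compound 2 to compound 3 in this assay is a 1.0-fold lower number from compound 2 to compound 3 (0.01 log units; within the scatter), essentially none beyond the scatter. Compound 3 is therefore estimated at 12000 nM, with a range from 5000 nM to 30000 nM.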

Compound 3, half-maximal inhibitory concentration: > 50000 nM
Compound 3 was reported as a limit; the forecaster's own chance of this, stated with the estimate: 10%; middle value at least 4.1-fold (0.61 log units) away from the limit.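

In this assay compound 3 reads > 50000 nM as its result, and this is a limit of the assay, not a number. Compound 1 and compound 2 gave no information about this carbon of the ring, but the change from 3-chlorophenyl to 3-chloro-4-fluorophenyl, a single fluoro group in place of hydrogen, now gives an at least 4.0-fold higher number from compound 2 to compound 3 (0.60 log units; beyond the scatter) as its step, so even one added atom at this position can make the compound a clearly weaker inhibitor in this assay. The step has a lower bound but no upper one, and it rests on a single result that is not an exact value: the limit of > 50000 nM in this assay, at which 1 of the 3 values shown sits.

As far as these compounds go, it remains open whether this loss is specific to fluoro or would also follow from a different group on the same carbon, such as a methoxy group, a methyl group or an amine. From the compounds shown here alone, it is also open whether the step depends on the chloro group that sits ortho to the new fluoro group, or would appear with a fluoro group alone on that ring.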